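Phenoxy pyrrolidine carboxamides: para-fluoro removal and microsomal clearance

The source may hold more compounds than are shown below. What is called first, only, known or untested is meant among the compounds shown, and "the series" means these compounds.

Measured so far:
- compound 1 `NC(=O)[C@@H]1CC[C@H](c2ccc(OCc3ccccc3F)cn2)N1`: 0.6 mL.min-1.g-1 in an ADME assay on microsomes from liver (Rattus norvegicus) for metabolic stability; on this read-out lower numbers stand for slow clearance and higher numbers for fast clearance
- compound 2 `NC(=O)[C@@H]1CC[C@H](c2ccc(Oc3ccc(F)cc3)cc2)N1`: 2 mL.min-1.g-1 in this assay

On this read-out compound 2 holds the highest of the two numbers. Its nearest neighbour is compound 1, whose number in this assay is lower by a gap that lies beyond the usual scatter. Going by the values given here, the two compounds differ in several places at once, so their values show only that compound 2 is cleared faster, and no single change can be held responsible.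

The next compound, compound 3 `NC(=O)[C@@H]1CC[C@H](c2ccc(Oc3ccccc3)cc2)N1`, is not yet measured. Relative to compound 2 it carries hydrogen in place of fluoro on an aromatic carbon. Among the compounds with values here, no pair of measured compounds differs by this change alone, so there is no measured step to lean on.

Within the data shown here, with no comparable step in hand, only a modest move in this assay is expected, most likely upward, and possibly not beyond the scatter. Compound 3 is therefore estimated at 3 mL.min-1.g-1, with a range from 1.2 mL.min-1.g-1 to 8 mL.min-1.g-1. The expected step from compound 2 is a 1.5-fold higher number from compound 2 to compound 3 (0.18 log units; within the scatter).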

Compound 3, intrinsic clearance in microsomes: 1.9 mL.min-1.g-1
The estimate for compound 3 lay 1.6-fold (0.20 log units) above the measured number; measured number inside the range.
By their numbers in this assay, from the lowest: compound 1; then compounds 3 and 2 (each within the scatter of the next).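

Hydrogen in place of fluoro on an aromatic carbon, para to a large group, gives a 1.1-fold lower number from compound 2 to compound 3 (0.02 log units; within the scatter) in this assay, the first step in the series that can be read at a single place. For the change from 4-fluorophenyl to phenyl, the fluoro therefore makes no difference that can be told from the scatter on this read-out, and compound 3 and compound 2 stand as equals here. Nothing measured on these compounds speaks to why the step is this small.

Still open, going by these compounds, is whether a larger group on the same aromatic carbon, such as methoxy, nitrile, trifluoromethyl or an amine, would move the number beyond the scatter, since a single exchange of fluoro for hydrogen says nothing about such groups. Also open, on these data alone, is whether the same exchange stays as small on the core of compound 1, which carries its own fluoro, so the result cannot yet be taken as a rule for the series.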